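This account rests on a few compounds, and the source may have more. Where it says the series, first, only, none or still open, it means among the compounds named here.

Measured compounds:
Compound 1, `Cn1nc2c(=O)n(CC3(O)CCN(Cc4ccc(-c5ccco5)cc4Cl)CC3)cnc2c1-c1ccc(C2(N)CC2)cc1`, gives 66.1 nM in an assay on isolated protein for inhibition of ubiquitin carboxyl-terminal hydrolase 7 (Homo sapiens), with stated times of 30 min and 2 h; a lower number here means a stronger inhibitor, a higher number a weaker inhibitor.
Compound 2, `Cn1nc2c(=O)n(CC3(O)CCN(Cc4ccc(-c5n[nH]c(=O)o5)cc4Cl)CC3)cnc2c1-c1ccc(CN)cc1`, gives 171 nM in this assay.
Compound 3, `Cc1ccc(-c2ccc(CN3CCC(O)(Cn4cnc5c(-c6ccc(CN)cc6)n(C)nc5c4=O)CC3)c(Cl)c2)s1`, gives 101 nM in this assay.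

Compound 3 holds the second highest of these three numbers. Its nearest neighbour is compound 1 and its furthest is compound 2, and both of those gaps lie within the usual scatter of this assay, so the three measured compounds cannot be told apart with confidence.

Compound 4, `Cn1nc2c(=O)n(CC3(O)CCN(Cc4ccc(-c5cncs5)cc4Cl)CC3)cnc2c1-c1ccc(CN)cc1`, differs from compound 3 in one place: 1,3-thiazol-5-yl in place of 5-methylthiophen-2-yl on an aromatic carbon. Among the measured compounds shown here, the only measured step that bears on such a change is a 1.7-fold lower number from compound 2 to compound 3 (0.23 log units; within the scatter), where one five-membered aromatic ring replaced another at the same aromatic carbon and the number moved only within the scatter. On that basis the exchange of one five-membered aromatic ring for another is expected to leave this assay about where it is, with no step beyond the scatter in either direction. Compound 4 is therefore estimated at 120 nM, with a range of 50 nM to 300 nM, which amounts to an expected step of a 1.2-fold higher number from compound 3 to compound 4 (0.07 log units; within the scatter).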

Compound 4, half-maximal inhibitory concentration: 117 nM
Estimate against measurement, compound 4: 1.0-fold (0.01 log units) above; measured number inside the range.
By their numbers in this assay, from the lowest: compounds 1, 3, 4 and 2 (each within the scatter of the next, the first and the last beyond it).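

The exchange of 5-methylthiophen-2-yl for 1,3-thiazol-5-yl on this aromatic carbon gives a 1.2-fold higher number from compound 3 to compound 4 (0.06 log units; within the scatter) in this assay, so going from one hetero atom in the ring to two does not move the number beyond the scatter. Replacing the five-membered aromatic ring with three hetero atoms by the same 1,3-thiazol-5-yl gives a 1.5-fold lower number from compound 2 to compound 4 (0.16 log units; within the scatter) and also stays within the scatter, so no step among these three compounds, with one, two or three hetero atoms in the ring, can be told from noise. Nothing at hand offers an explanation for this lack of separation.

The compounds shown leave open whether this aromatic carbon responds to anything other than a five-membered aromatic ring. A pyridine ring, a carboxylic acid or an aminomethyl group in the same place would test whether the numbers stay this close.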